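Ethenyl chain variants on the benzyl arm of compound 2

The source may report more compounds than this note shows. Statements on the series, on what has been measured and on what is new or still open speak of the compounds shown alone.

The measured compounds are:
compound 1, `COC(=O)/C=C/c1cccc(N(Cc2ccc(-c3cccc(C)c3)cc2)C(=O)C2CCCCC2)c1`, 109 nM
compound 2, `COC(=O)/C=C/c1cccc(N(Cc2ccc(/C=C/C(=O)N(C)C)cc2)C(=O)C2CCCCC2)c1`, > 1000 nM

Compound 2 reaches only a limit in an assay on isolated protein with Bile acid receptor (Homo sapiens) as the target (on this read-out higher numbers stand for an effect only at larger amounts of compound and lower numbers for an effect already at smaller amounts), which is the limit given by the limit of > 1000 nM in this assay, at which 1 of the 2 values shown sits. For the measured compounds named here, the single measured step, an at least 9.1-fold higher number from compound 1 to compound 2 (0.96 log units; beyond the scatter), shows that exchanging the 3-methylphenyl group for the 2-(dimethylcarbamoyl)ethenyl chain costs activity, though the size of that loss is open because compound 2 sits at the limit.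

Compound 3, `CCOC/C=C/c1ccc(CN(C(=O)C2CCCCC2)c2cccc(/C=C/C(=O)OC)c2)cc1`, keeps the chain of compound 2 and changes its end: ethoxymethyl in place of dimethylcarbamoyl on a double-bonded chain carbon bound to a double-bonded chain carbon. Going by the values given here, no measured step touches this exact change; the only comparison available is between two groups of different shape, so its bearing on compound 3 is indirect. An ethoxymethyl end is expected to leave compound 3 near where compound 2 stands, with a step that the limit leaves unreadable from compound 2 to compound 3 counted as the expected step in this assay. Compound 3 is therefore estimated at 1500 nM, within 400 nM to 6000 nM.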

Compound 3, half-maximal effective concentration: 198000 nM
The estimate for compound 3 lay 130-fold (2.12 log units) below the measured number; the measured number lies above the stated range.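

In this assay, for the compounds shown here, the exchange of 3-methylphenyl for 3-ethoxyprop-1-en-1-yl on an aromatic carbon gives a 1800-fold higher number from compound 1 to compound 3 (3.26 log units; beyond the scatter), which puts a readable size on a loss at this position for the first time. Both chains now stand on the side of higher numbers relative to the 3-methylphenyl group of compound 1, each by a step beyond the usual scatter. Compound 2 is held at a limit, so its step to compound 3 cannot be read, and the ethoxymethyl and dimethylcarbamoyl ends cannot be ranked against each other: the limit of > 1000 nM in this assay, at which 1 of the 3 values shown sits.

Going by these compounds, whether the loss follows from the chain as a whole or from the group at its end stays open. Also open, on these data alone, is how a chain ending in a carboxylic acid or an amine, or a phenyl ring bearing a methoxy group, would read in this assay.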